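Adding trifluoromethyl to the phenyl ring of compound 3

A few compounds are considered here, and "the series" means these few. Any claim that something is new, unique, unknown or untested is made for them only; others in the source may bear on it.

Compound 1 `N=C(NS(=O)(=O)c1ccccc1)N1CCN(c2cc3c(cc2F)c(=O)c(C(=O)O)cn3C2CC2)CC1` gives 32 nM
Compound 2 `CCn1cc(C(=O)O)c(=O)c2cc(F)c(N3CCN(C(=N)NS(=O)(=O)c4cccc(Cl)c4)CC3)cc21` gives 32 nM
Compound 3 `CCn1cc(C(=O)O)c(=O)c2cc(F)c(N3CCN(C(=N)NS(=O)(=O)c4ccccc4)CC3)cc21` gives 32 nM

In a functional assay on HeLa cells (Homo sapiens) for antiproliferative activity, read by MTT assay, with a stated time of 72 h (on this read-out lower numbers stand for stronger inhibition and higher numbers for weaker inhibition), compound 3 gives 32 nM and stands level with compound 1 and compound 2. Compound 4 `CCn1cc(C(=O)O)c(=O)c2cc(F)c(N3CCN(C(=N)NS(=O)(=O)c4ccccc4C(F)(F)F)CC3)cc21` carries trifluoromethyl in place of hydrogen on an aromatic carbon and differs from compound 3 in nothing else. The nearest evidence is the chloro swap on an aromatic carbon, no change at the digits printed from compound 2 to compound 3 (within the scatter) and the ethyl swap elsewhere, no change at the digits printed from compound 1 to compound 3 (within the scatter) also left the value unmoved. Within the data shown here, no measured compound carries trifluoromethyl, so the range stays wide. The expected step of a 1.1-fold higher number from compound 3 to compound 4 (0.04 log units; within the scatter) has no favoured direction and should stay within the scatter. Compound 4 is estimated at 35 nM with an expected range from 12 nM to 100 nM once measured.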

Compound 4, half-maximal inhibitory concentration: 32 nM
For compound 4 the middle estimate is 1.1-fold (0.04 log units) above the measured one; measured number inside the range.
By their numbers in this assay, from the lowest: compounds 1, 2, 3 and 4 (each within the scatter of the next).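

In this assay, trifluoromethyl on the phenyl ring, ortho to a large group, gives no change at the digits printed from compound 3 to compound 4 (within the scatter), so this larger group is tolerated at this position. Putting 2-(trifluoromethyl)phenyl in place of 3-chlorophenyl gives no change at the digits printed from compound 2 to compound 4 (within the scatter), so hydrogen, chloro and trifluoromethyl on this ring all leave the number level across compounds 2, 3 and 4. Nothing measured here accounts for this flat result. Still open, from the compounds shown here alone, is whether a different kind of group on this ring, such as an amine, a carboxylic acid or a longer chain, would shift the number.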